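Adding a chloro to compound 2

This account rests on a few compounds, and the source may have more. Where it says the series, first, only, none or still open, it means among the compounds named here.

Compound 1 `O=S(=O)(N/C(=N\O)Nc1ccc(Cl)cc1)c1cc2ccccc2o1`: > 200 ug/mL
Compound 2 `O=[N+]([O-])c1ccc(Oc2c(Cl)cc(S(=O)(=O)N/C(=N\O)Nc3ccc(Cl)cc3)cc2Cl)cc1`: 22 ug/mL

Both compounds were tested in a functional assay on HepG2 cells (Homo sapiens) for cytotoxicity; on this read-out higher numbers stand for weaker inhibition and lower numbers for stronger inhibition. For compound 1, the entry > 200 ug/mL is a limit of the assay and not a number. Among the compounds with values here, compound 2, at 22 ug/mL, therefore holds the only true number so far, and no measured value can yet be ranked against it.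

Compound 3 `O=[N+]([O-])c1ccc(Oc2c(Cl)cc(S(=O)(=O)N/C(=N\O)Nc3ccc(Cl)cc3)cc2Cl)c(Cl)c1` awaits measurement. It differs from compound 2 by chloro in place of hydrogen on an aromatic carbon, turning 4-nitrophenyl into 2-chloro-4-nitrophenyl. Within the data shown here, no measured pair shows the effect of this change, so the expectation rests on compound 2 at 22 ug/mL. A modest shift towards stronger inhibition is expected, close to the usual scatter, and the expected step is a 1.5-fold lower number from compound 2 to compound 3 (0.17 log units; within the scatter). Compound 3 is estimated at 15 ug/mL, with an expected range of 6 ug/mL to 40 ug/mL.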

Compound 3, half-maximal inhibitory concentration: 49 ug/mL
For compound 3 the middle estimate is 3.3-fold (0.51 log units) below the measured one; the measured number lies above the stated range.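

In this assay, chloro in place of hydrogen on an aromatic carbon, ortho to a large group and meta to the nitro group, gives a 2.2-fold higher number from compound 2 to compound 3 (0.35 log units; beyond the scatter) and so weakens inhibition on this read-out. Within the data shown here, this is the first measured pair to address this place on the 4-nitrophenoxy ring, and it shows that a single added chlorine atom there is enough to move the number beyond the usual scatter. Nothing shown here accounts for the direction of this step.

The compounds shown leave open whether this shift is particular to chloro or would also follow from a fluoro, a methyl or an amine at the same place. They also leave open how chloro would act on the other aromatic carbons of this ring.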